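The source may report more compounds than this note shows. Statements on the series, on what has been measured and on what is new or still open speak of the compounds shown alone.

In a functional assay on SW-620 cells (Homo sapiens) for antiproliferative activity, read by CCK-8 assay and cell counting, with a stated time of 72 h (a lower number here means a stronger inhibitor, a higher number a weaker inhibitor), compound 1 (`O=C(Nc1ccccc1OC(=O)c1ccc(CCl)cc1)c1ccc(CCl)cc1`) gives 800 nM and compound 2 (`O=C(Nc1ccccc1)c1ccc(CO[N+](=O)[O-])cc1`) gives 800 nM, so compound 2 stands level with compound 1, within the usual scatter. Compound 3 (`O=C(Nc1ccccc1)c1ccc(CO)cc1`) differs from compound 2 in one place: hydrogen in place of nitro on an oxygen on a saturated carbon. In words, hydrogen replaces nitro on an oxygen on a saturated carbon, turning nitrooxy to hydroxy. Within the data shown here, no measured pair shows this change, so the expectation is only a judgement: a clearly weaker inhibitor, with an expected step of a 6.3-fold higher number from compound 2 to compound 3 (0.80 log units; beyond the scatter). For compound 3, the estimated value in this assay is 5000 nM, with an expected range of 1000 nM to 30000 nM.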

Compound 3, half-maximal inhibitory concentration: > 100000 nM
Compound 3 gave a limit, no number; the forecaster's own chance of this, stated with the estimate: 30%; middle value at least 20-fold (1.30 log units) away from the limit.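

Turning nitrooxy to hydroxy on this saturated carbon gives an at least 120-fold higher number from compound 2 to compound 3 (2.09 log units; beyond the scatter), the first sign that activity at this position depends heavily on the nitro on the oxygen. Compound 3 gives a limit and not a number: the limit of > 100000 nM in this assay, at which 1 of the 3 values shown sits.

From the compounds shown here alone, the full size of the step therefore stays unknown. The compounds shown also leave open whether a different group at this place, such as a methyl ether or an amine, would keep the activity of compound 2 or lose it as compound 3 does.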